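The compounds below may be only part of what the source reports. "The series", "measured", "known", "first", "only" and "open" are said of these compounds alone.

Measured in a functional assay on MCF7 cells (Homo sapiens) for inhibition, read by CCK-8 assay, with a stated time of 48 h; on this read-out higher numbers stand for weaker inhibition and lower numbers for stronger inhibition:
- compound 1 `COc1cc(-c2ccnc3cc(-c4ccc(Cl)cc4)nn23)cc(OC)c1OC`: 2320 nM
- compound 2 `COc1cc(-c2ccnc3cc(-c4ccc(C)cc4)nn23)cc(OC)c1OC`: 47 nM
- compound 3 `COc1cc(-c2ccnc3cc(-c4ccc5cc[nH]c5c4)nn23)cc(OC)c1OC`: 23 nM

Compound 3 has the lowest number of the three, and so shows the strongest inhibition in this assay. The next step leads to compound 4 `COc1cc(-c2ccnc3cc(-c4ccc(C(F)(F)F)cc4)nn23)cc(OC)c1OC`, with 4-(trifluoromethyl)phenyl in place of 1H-indol-6-yl on an aromatic carbon.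

Two measured steps make the same kind of exchange between a substituted phenyl and 1H-indol-6-yl. The step of a 2.0-fold lower number from compound 2 to compound 3 (0.31 log units; beyond the scatter) is modest, while the step of a 100-fold lower number from compound 1 to compound 3 (2.00 log units; beyond the scatter) is large. The outcome therefore depends heavily on the group carried by the phenyl ring, as the large step of a 49-fold lower number from compound 1 to compound 2 (1.69 log units; beyond the scatter) also shows. Going by the values given here, no measured compound carries trifluoromethyl, so the size of the step cannot be read directly. A rise in the number is expected, of a size somewhere between those two steps.

The expected step is a 17-fold higher number from compound 3 to compound 4 (1.24 log units; beyond the scatter), towards weaker inhibition. For compound 4 the estimated value is 400 nM, with an expected range from 70 nM to 2500 nM.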

Compound 4, half-maximal inhibitory concentration: 2440 nM
Estimate against measurement, compound 4: 6.1-fold (0.79 log units) below; the measured number falls inside the stated range.
By their numbers in this assay, from the lowest: compound 3; then compound 2; then compounds 1 and 4 (each within the scatter of the next).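

In this assay, trifluoromethyl on the phenyl ring gives a result that cannot be told apart from chloro, with a 1.1-fold higher number from compound 1 to compound 4 (0.02 log units; within the scatter), but it differs sharply from methyl, with a 52-fold higher number from compound 2 to compound 4 (1.72 log units; beyond the scatter). Among these four compounds, 1H-indol-6-yl and 4-methylphenyl therefore give low numbers, while 4-chlorophenyl and 4-(trifluoromethyl)phenyl give high numbers, and the exchange on this aromatic carbon spans that divide, with a 110-fold higher number from compound 3 to compound 4 (2.03 log units; beyond the scatter). No measurement available here explains why chloro and trifluoromethyl go together and methyl stands apart.

As far as these compounds go, it remains open whether other groups on the phenyl ring, such as methoxy, an amine or a longer chain like ethyl, would match methyl or chloro. Also open, from the compounds shown here alone, is whether a methyl on the indole nitrogen would keep the low number of compound 3.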